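Adding an Amino Group Next to the Ring Oxygen

The source may hold more compounds than are shown below. What is called first, only, known or untested is meant among the compounds shown, and "the series" means these compounds.

Measured compounds:
compound 1, `Cc1cc2oc(N)c(/C=N/NCCO)c(=O)c2cc1C`, 65300 nM
compound 2, `COC(=O)N/N=C/c1coc2ccccc2c1=O`, 309000 nM

Both compounds were tested in a functional assay on NALM-6 cells (Homo sapiens) for cytotoxicity, read by MTT assay, with a stated time of 48 h; on this read-out higher numbers stand for weaker inhibition and lower numbers for stronger inhibition. Compound 2 gives the highest of the two numbers; compound 1 gives a number that lies well beyond the scatter below it, although the two structures differ in several places, so nothing can be said about any single cause.

Compound 3, `COC(=O)N/N=C/c1c(N)oc2ccccc2c1=O`, has not yet been measured. It differs from compound 2 by one change: amino in place of hydrogen on an aromatic carbon, placed next to the ring oxygen, ortho to a group of 7 heavy atoms. Compound 1 carries an amino group in the same position on its core and gives 65300 nM, which is the only hint available.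

On that basis a step toward a lower number is expected, a 2.6-fold lower number from compound 2 to compound 3 (0.41 log units; beyond the scatter), of moderate size. Compound 3 is estimated at 120000 nM, with a range from 40000 nM to 400000 nM.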

Compound 3, half-maximal inhibitory concentration: 407000 nM
Compound 3: the middle estimate sits 3.4-fold (0.53 log units) below what was measured; measured number outside the range, above it.
By their numbers in this assay, from the lowest: compound 1; then compounds 2 and 3 (each within the scatter of the next).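

In this assay, amino in place of hydrogen on an aromatic carbon, next to the ring oxygen, gives a 1.3-fold higher number from compound 2 to compound 3 (0.12 log units; within the scatter), so on this core the change leaves no mark that can be told from the scatter. The hint from compound 1 therefore does not carry over to this pair, and because compound 1 differs from compound 3 in several places, what lies behind its number cannot be read from these compounds. No measured property of these compounds bears on this result.

The compounds shown leave open whether a methyl or a dimethylamino group at this same place would also stay within the scatter of hydrogen. They also leave open whether amino would count for more on the core of compound 1, with its own side chain.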